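Swapping the indole nitrogen substituent: from chlorobenzoyl to benzyl

The source may report more compounds than this note shows. Statements on the series, on what has been measured and on what is new or still open speak of the compounds shown alone.

The measured compounds and their values:
compound 1, `O=C1COCCN1c1ccc(/N=C\c2c[nH]c3ccccc23)cc1`, 97.8%
compound 2, `Cc1ccc(S(=O)(=O)n2cc(/C=N\c3ccc(N4CCOCC4=O)cc3)c3ccccc32)cc1`, 57.8%
compound 3, `O=C1COCCN1c1ccc(/N=C\c2cn(C(=O)c3ccc(Cl)cc3)c3ccccc23)cc1`, 90.3%

These three compounds were tested in an ADME assay on BV-2 cells (Mus musculus) for cytotoxicity, read by MTT assay, with a stated time of 48 h, tested at 80 uM; a lower number here means a stronger effect, a higher number a weaker effect of the compound at the concentration tested. Compound 3 stands second highest of the three numbers with 90.3%; the nearest is compound 1 with 97.8%, and the change a number 7.5 percentage points lower from compound 1 to compound 3 (within the scatter) stays within the scatter. The furthest is compound 2 with 57.8%, and the step of a number 32.5 percentage points higher from compound 2 to compound 3 (beyond the scatter) is large.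

Compound 4, `O=C1COCCN1c1ccc(/N=C\c2cn(Cc3ccccc3)c3ccccc23)cc1`, has not yet been measured. It differs from compound 3 in one place: benzyl in place of (4-chlorophenyl)carbonyl on an aromatic nitrogen. Among the measured compounds shown here, no measured step exchanges one group for another of this kind on the aromatic nitrogen. For the measured compounds named here, the steps that bear on it are those at the same position: a number 7.5 percentage points lower from compound 1 to compound 3 (within the scatter) was small, a number 40 percentage points lower from compound 1 to compound 2 (beyond the scatter) was large, and a number 32.5 percentage points higher from compound 2 to compound 3 (beyond the scatter) was large, so a group on this nitrogen can either leave the number near that of compound 1 or lower it strongly.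

Compound 4 is therefore expected to give 88% in this assay, with a range from 65% to 100%. This estimate means a step of a number 2.3 percentage points lower from compound 3 to compound 4 (within the scatter), which is expected to lie within the scatter.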

Compound 4, a percentage reported as activity, at one concentration (the size of the read-out at that concentration, not a potency): 58.7%
For compound 4 the middle estimate is 29.3 percentage points above the measured one, and the stated range ends above it.
By their numbers in this assay, from the lowest: compounds 2 and 4 (each within the scatter of the next); then compounds 3 and 1 (each within the scatter of the next).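

In this assay, the step of a number 31.6 percentage points lower from compound 3 to compound 4 (beyond the scatter) is large, although benzyl and (4-chlorophenyl)carbonyl each bring one six-membered aromatic ring of carbon only, so having such a ring on this aromatic nitrogen does not by itself keep the number near that of compound 1. The step of a number 39.1 percentage points lower from compound 1 to compound 4 (beyond the scatter) makes benzyl a second group, after (4-methylphenyl)sulfonyl, that strongly lowers the number, and the step of a number 0.9 percentage points higher from compound 2 to compound 4 (within the scatter) puts these two groups level, so among the compounds shown a strong effect is not tied to the sulfonyl group, with (4-chlorophenyl)carbonyl the one substituent that goes against this lowering. Nothing available here explains why these groups differ in this way.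

The compounds shown cannot separate the part played by the carbonyl from that of the chlorine, since they include neither a plain benzoyl group nor a benzyl group carrying a chlorine. Also open, going by these compounds, is what a small methyl group, or a longer chain ending in an amine, would do on this nitrogen.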